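Moving a furan attachment point on a second dihydropyrimidinone core

This account rests on a few compounds, and the source may have more. Where it says the series, first, only, none or still open, it means among the compounds named here.

The measurement here is an assay on membranes from CHO cells for displacement of a labelled ligand from adenosine receptor A1 (Homo sapiens), read by scintillation counting, with a stated time of 60 min, tested at 1 uM; on this read-out lower numbers stand for less inhibition and higher numbers for more inhibition at the one concentration tested (going by the name of the read-out). Compound 1, with the structure `CCSC(=O)C1=C(C)NC(=O)NC1c1ccco1`, gives 6% in this assay. Compound 2, with the structure `CCSC(=O)C1=C(C)NC(=O)NC1c1ccoc1`, gives 3%. The change between them is furan-3-yl in place of furan-2-yl on a saturated ring carbon, and it made a step of a number 3 percentage points lower from compound 1 to compound 2 (within the scatter), so these two compounds cannot be told apart on this read-out. Compound 3, with the structure `CC1=C(c2ncc(C)o2)C(c2ccco2)NC(=O)N1`, gives 27%, the highest of the three numbers. Its core differs from the core of compound 1 by 5-methyl-1,3-oxazol-2-yl in place of (ethylsulfanyl)carbonyl on a double-bonded ring carbon, a change that made a step of a number 21 percentage points higher from compound 1 to compound 3 (beyond the scatter).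

Compound 4, with the structure `CC1=C(c2ncc(C)o2)C(c2ccoc2)NC(=O)N1`, has not been measured. It differs from compound 3 by furan-3-yl in place of furan-2-yl on a saturated ring carbon. Within the data shown here, this is the same kind of change as the one from compound 1 to compound 2, but not the same: in compound 4 the saturated ring carbon sits next to the ring atom that bears a 5-methyl-1,3-oxazol-2-yl group, whereas in compound 2 it sits next to the ring atom that bears a (ethylsulfanyl)carbonyl group. Among the measured compounds shown here, since the step from compound 1 to compound 2 stayed within the scatter, the step of a number 3 percentage points lower from compound 3 to compound 4 (within the scatter) is expected to be similarly small, an expectation resting on the single measured pair only. Compound 4 is therefore estimated to give about 24%, with a range from 10% to 38%.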

Compound 4, a percentage reported as inhibition, at one concentration (the size of the read-out at that concentration, not a potency): 21%
Beside the measured number, compound 4's estimate is 3 percentage points above it; the measured number falls inside the stated range.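

On the core that carries the 5-methyl-1,3-oxazol-2-yl group, furan-3-yl in place of furan-2-yl on the saturated ring carbon made a step of a number 6 percentage points lower from compound 3 to compound 4 (within the scatter) in this assay, so this swap leaves no readable mark on either core, and the two steps agree: the same change on two cores in this assay, a number 3 percentage points lower (within the scatter) from compound 1 to compound 2 and a number 6 percentage points lower (within the scatter) from compound 3 to compound 4, 3 percentage points apart, within the scatter of two such steps. The change of the other group also carried over, since 5-methyl-1,3-oxazol-2-yl in place of (ethylsulfanyl)carbonyl made a step of a number 18 percentage points higher from compound 2 to compound 4 (beyond the scatter) with furan-3-yl in the molecule, in line with the step seen with furan-2-yl: the same change on two cores in this assay, a number 21 percentage points higher (beyond the scatter) from compound 1 to compound 3 and a number 18 percentage points higher (beyond the scatter) from compound 2 to compound 4, 3 percentage points apart, within the scatter of two such steps. This shows that within these four compounds each change kept its size when the other group was swapped, but it rests on just two pairs per change, tested at one concentration, so it neither proves that the furan attachment point is irrelevant nor predicts the outcome on any other core.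

From the compounds shown here alone, it remains open how a phenyl ring or a thiophene ring would read in place of the furan on the saturated ring carbon. Going by these compounds, it is also open whether a carboxylic acid or an amide in place of the 5-methyl-1,3-oxazol-2-yl group would follow the same step.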